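Same Atoms, Joined Differently: A Stability Question

The source may hold more compounds than are shown below. What is called first, only, known or untested is meant among the compounds shown, and "the series" means these compounds.

Among the compounds with values here, only two compounds have been measured so far, compound 1 `CN(C[C@@H]1Cc2c(cccc2N2CCNCC2)CN1)[C@H]1CCCc2cccnc21` and compound 2 `CN(C[C@H]1Cc2c(cccc2N2CCN(C3CC3)CC2)CN1)[C@H]1CCCc2cccnc21`. In an ADME assay on microsomes from liver (Homo sapiens) for metabolic stability, read by LC-MS, with a stated time of 10 min (a lower number here means that less of the compound is left, a higher number that more of the compound is left), compound 1 gives 94.2%. Compound 2 gives 15.5%, the lower of the two numbers, and the gap between them lies well beyond the usual scatter.

Compound 3 `CN(C[C@H]1Cc2c(cccc2N2CCN3CCC[C@H]3C2)CN1)[C@H]1CCCc2cccnc21` starts from compound 2 and changes one group on an aromatic carbon: the 4-cyclopropylpiperazin-1-yl group is replaced, keeping the same atoms but joining them differently, (a group of 9 heavy atoms (7 carbon, 2 nitrogen; one five-membered non-aromatic ring with 1 hetero atom, one six-membered non-aromatic ring with 2 hetero atoms) in place of a group of 9 heavy atoms (7 carbon, 2 nitrogen; one three-membered non-aromatic ring of carbon only, one six-membered non-aromatic ring with 2 hetero atoms), on an aromatic carbon).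

Compound 1 and compound 2 differ in more than one place, so their gap offers no clean measure of this change. Compound 2 sits at 15.5%, which leaves far more room to rise than to fall. A modest upward change is therefore expected, only a little beyond the scatter, with the estimated step of a number 14.5 percentage points higher from compound 2 to compound 3 (beyond the scatter). For compound 3 the estimated value is 30%, with an expected range from 10% to 60%.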

Compound 3, percent of the compound remaining: 36.6%
Compound 3: the middle estimate sits 6.6 percentage points below what was measured; low and high end bracket the measured number.
By their numbers in this assay, from the lowest: compound 2; then compound 3; then compound 1.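

Within the data shown here, replacing the 4-cyclopropylpiperazin-1-yl group on this aromatic carbon with the group that carries a five-membered and a six-membered non-aromatic ring gives a number 21.1 percentage points higher from compound 2 to compound 3 (beyond the scatter) in this assay and provides the first clean one-place comparison. The two groups have the same atoms and the same counts of hydrogen-bond donors and acceptors, so the result shows that how those atoms are joined can matter at this position, even with the composition held constant. The measurements on hand offer nothing that explains why the number rises, and the change may not be assigned to any particular property of either group.

Among these compounds, compound 1 differs from the others in more than one place, so no step involving it can be read, and what its unsubstituted piperazine contributes remains unresolved. Also open, on these data alone, is whether a small alkyl group such as methyl or ethyl on the piperazine nitrogen, or the opposite arrangement at the defined stereocentre of the entering group, would shift the number further in either direction.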